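The compounds below may be only part of what the source reports. "The series", "measured", "known", "first", "only" and "open" are said of these compounds alone.

Among the measured compounds shown here, the two compounds measured so far share one core and differ only in what sits on the amide-type nitrogen in the ring. Compound 1 `CC(C)(C)c1cc(NC(=O)[C@@H]2CCCCN2C2CC2)no1` gives, in a physicochemical assay for solubility, read by HPLC, at pH 6.8 (a lower number here means a less soluble compound, a higher number a more soluble compound), a solubility of 38 ug/mL. Compound 2 `CC(C)(C)c1cc(NC(=O)[C@@H]2CCCCN2C(=O)C2CCS(=O)(=O)CC2)no1` gives, in this assay, a solubility of 67 ug/mL. Compound 2 thus holds the higher of the two numbers, yet its gap to compound 1 lies within the scatter, so no order between the two can be read from these figures. Compound 3 `CC(C)(C)c1cc(NC(=O)[C@@H]2CCCCN2C(=O)CC2CCOCC2)no1` has not yet been measured; it follows from compound 2 by a single change on a carbonyl carbon whose other neighbour is the amide-type nitrogen in the ring: (oxan-4-yl)methyl in place of 1,1-dioxothian-4-yl on a carbonyl carbon. For the measured compounds named here, no step between measured compounds covers an exchange of this kind, so nothing measured here shows how far the number moves. The expectation for compound 3 is a downward step a 2.2-fold lower number from compound 2 to compound 3 (0.35 log units; beyond the scatter), of a size that would just reach beyond the scatter. On that basis compound 3 is expected to give 30 ug/mL in this assay, with a range from 10 ug/mL to 90 ug/mL.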

Compound 3, solubility: 52 ug/mL
Compound 3: middle estimate off by 1.7-fold (0.24 log units), on the low side; low and high end bracket the measured number.
By their numbers in this assay, from the lowest: compounds 1, 3 and 2 (each within the scatter of the next).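

In this assay, the exchange at the carbonyl carbon whose other neighbour is the amide-type nitrogen in a ring gives a 1.3-fold lower number from compound 2 to compound 3 (0.11 log units; within the scatter), so going from 1,1-dioxothian-4-yl, with 2 hydrogen-bond acceptors, to (oxan-4-yl)methyl, with 1, produces no readable shift in solubility. The exchange on the amine nitrogen in a ring, ((oxan-4-yl)methyl)carbonyl in place of cyclopropyl, gives a 1.4-fold higher number from compound 1 to compound 3 (0.14 log units; within the scatter), so this second change, too, cannot be told apart from repeated measurement, and the three compounds cannot be put in any order. Nothing measured alongside these numbers offers an explanation for them.

As far as these compounds go, the step from compound 2 to compound 3 changes the ring and adds a methylene at once, so it remains open what each part contributes alone, which a plain oxan-4-yl or a (1,1-dioxothian-4-yl)methyl group on the same carbonyl carbon would separate. From the compounds shown here alone, it also remains open whether a group of another kind there, such as an amine or a carboxylic acid, would move the number beyond the scatter.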